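The source may hold more compounds than are shown below. What is called first, only, known or untested is meant among the compounds shown, and "the series" means these compounds.

Working notes, chalcone-type series on a shared core.

Compound 1 `COc1ccc(-c2cc(C(=O)/C=C/c3ccc(Cl)cc3)nc3cc(-c4ccccc4)nn23)cc1OC` gives 22000 nM in a functional assay on A549 cells (Homo sapiens) for antiproliferative activity, read by MTT assay, with a stated time of 24 h; a lower number here means a stronger inhibitor, a higher number a weaker inhibitor. Compound 2 `COc1ccc(-c2cc(/C=C/C(=O)c3ccc(C)c(C)c3)nc3cc(-c4ccccc4)nn23)cc1OC` gives 9300 nM, a change of a 2.4-fold lower number from compound 1 to compound 2 (0.37 log units; beyond the scatter). Compound 3 `COc1ccc(C(=O)/C=C/c2cc(-c3ccc(OC)c(OC)c3)n3nc(-c4ccccc4)cc3n2)cc1OC` gives 3900 nM, with a 2.4-fold lower number from compound 2 to compound 3 (0.38 log units; beyond the scatter). Compound 3 therefore carries the lowest number of the three measured; compound 2 is nearest to it and compound 1 furthest, both separations beyond the scatter.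

Compound 4 `COc1ccc(-c2cc(/C=C/C(=O)c3ccccc3)nc3cc(-c4ccccc4)nn23)cc1OC` differs from compound 3 by phenyl in place of 3,4-dimethoxyphenyl on a carbonyl carbon. Within the data shown here, the step that bears on this is the one from compound 2 to compound 3, where putting 3,4-dimethoxyphenyl on the carbonyl carbon in place of 3,4-dimethylphenyl brought a modest lowering; compound 4 removes the methoxy substituents again, so a modest rise is expected in this assay. The step from compound 1 to compound 2 concerns the orientation of the enone and does not bear on it. Among the measured compounds shown here, no measured pair shows plain phenyl against 3,4-dimethylphenyl, so the size is taken from compound 3 at 3900 nM and the step from compound 2 to compound 3 alone. Compound 4 is expected at about 9000 nM, a step of a 2.3-fold higher number from compound 3 to compound 4 (0.36 log units; beyond the scatter), between 3500 nM and 25000 nM.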

Compound 4, half-maximal inhibitory concentration: 10700 nM
For compound 4 the middle estimate is 1.2-fold (0.08 log units) below the measured one, within the range that was stated.
By their numbers in this assay, from the lowest: compound 3; then compounds 2 and 4 (each within the scatter of the next); then compound 1.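

On the carbonyl carbon in this assay, 3,4-dimethoxyphenyl now stands directly against plain phenyl, with a 2.7-fold higher number from compound 3 to compound 4 (0.44 log units; beyond the scatter) as the step. 3,4-Dimethylphenyl and phenyl are not separated at this place, with a 1.2-fold higher number from compound 2 to compound 4 (0.06 log units; within the scatter) as the step, so among these three groups only 3,4-dimethoxyphenyl stands apart from the other two. The step with a 2.1-fold lower number from compound 1 to compound 4 (0.31 log units; beyond the scatter) as its reading replaces (2-(4-chlorophenyl)ethenyl)carbonyl with 2-benzoylethenyl as a whole, so it cannot separate the orientation of the enone from the change of the outer aryl group.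

Nothing measured here gives a reason for these steps. Open, as far as these compounds go, is whether a single methoxy group, an amine or a carboxylic acid on the phenyl ring at this carbonyl carbon would give a number like that of compound 3.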